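Swapping the Nitrile on the Amide Chain for a Hydroxy Group

The source may report more compounds than this note shows. Statements on the series, on what has been measured and on what is new or still open speak of the compounds shown alone.

Compound 1 `NS(=O)(=O)CC(=O)NCCSc1nonc1/C(=N/O)Nc1ccc(F)c(C(F)F)c1` gives 13 nM in an assay for inhibition of Indoleamine 2,3-dioxygenase 1 (Homo sapiens), read by fluorescence, with a stated time of 24 h; on this read-out lower numbers stand for stronger inhibition and higher numbers for weaker inhibition.
Compound 2 `CC1(C(=O)NCCSc2nonc2/C(=N/O)Nc2ccc(F)c(C(F)F)c2)CCN1` gives 16 nM in this assay.
Compound 3 `N#CCC(=O)NCCSc1nonc1/C(=N/O)Nc1ccc(F)c(C(F)F)c1` gives 6.5 nM in this assay.

Within the data shown here, compound 3 holds the lowest of the three numbers, though its gap to compound 1 is within the scatter; only the step of a 2.5-fold lower number from compound 2 to compound 3 (0.39 log units; beyond the scatter) is beyond it. Compound 4 `CC(C)(O)CC(=O)NCCSc1nonc1/C(=N/O)Nc1ccc(F)c(C(F)F)c1` differs from compound 3 by 1-hydroxy-1-methylethyl in place of cyano on a saturated chain carbon bound to a carbonyl carbon. The step of a 2.0-fold lower number from compound 1 to compound 3 (0.30 log units; within the scatter) is the closest guide, since it also exchanges the group on a saturated chain carbon bound to a carbonyl carbon and stays within the scatter. The step of a 1.2-fold higher number from compound 1 to compound 2 (0.09 log units; within the scatter), which alters the group on the carbonyl carbon, is small as well. A small rise in the number, at most near the edge of the scatter, is therefore expected: a 1.7-fold higher number from compound 3 to compound 4 (0.23 log units; within the scatter). Compound 4 is estimated at 11 nM, with a range from 4.5 nM to 27 nM.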

Compound 4, half-maximal inhibitory concentration: 8.4 nM
The estimate for compound 4 lay 1.3-fold (0.12 log units) above the measured number, within the range that was stated.
By their numbers in this assay, from the lowest: compounds 3, 4, 1 and 2 (each within the scatter of the next, the first and the last beyond it).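

At the saturated chain carbon bound to a carbonyl carbon, 1-hydroxy-1-methylethyl, with 1 hydrogen-bond donor, replaces cyano, with no donor, and this assay shows a 1.3-fold higher number from compound 3 to compound 4 (0.11 log units; within the scatter). Replacing sulfamoyl at that place gives a 1.5-fold lower number from compound 1 to compound 4 (0.19 log units; within the scatter) and replacing the four-membered ring group on the carbonyl carbon gives a 1.9-fold lower number from compound 2 to compound 4 (0.28 log units; within the scatter), so this part of the molecule tolerates quite different groups. No measurement here gives a reason for that tolerance. From the compounds shown here alone, whether an amine, a carboxylic acid or a longer chain at this place would keep the number in the same range remains open.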